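This account rests on a few compounds, and the source may have more. Where it says the series, first, only, none or still open, it means among the compounds named here.

Series notes. In an assay on cells for agonist activity at vitamin D3 receptor (Homo sapiens), read by microscopy (on this read-out higher numbers stand for an effect only at larger amounts of compound and lower numbers for an effect already at smaller amounts), compound 1 `CCN(CC)CCNC(=O)c1ccc(C(CC)(CC)c2ccc(OCC(O)C(C)(C)C)c(C)c2)n1CC` gives 6.54 nM and compound 2 `CCn1cc(C(CC)(CC)c2ccc(C#CC(O)(CC)CC)c(C)c2)cc1C(=O)NCCN(C)C` gives 19.3 nM; compound 2 therefore stands as the higher of the two numbers, compound 1 as the lower, and the gap between them lies beyond the scatter. Compound 3 `CCn1cc(C(CC)(CC)c2ccc(C#CC(O)(CC)CC)c(C)c2)cc1C(=O)N[C@@H](C(=O)O)C(C)C` differs from compound 2 in one place: 1-carboxy-2-methylpropyl in place of 2-(dimethylamino)ethyl on an amide-type nitrogen. Among the compounds with values here, no measured pair shows this change, so the expected step of a 1.5-fold higher number from compound 2 to compound 3 (0.16 log units; within the scatter) is set small and toward a higher number, within or close to the scatter. For compound 3 the estimated value is 28 nM, with a range from 8 nM to 90 nM.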

Compound 3, half-maximal effective concentration: 68.3 nM
Compound 3: the middle estimate sits 2.4-fold (0.39 log units) below what was measured; measured number inside the range.
By their numbers in this assay, from the lowest: compound 1; then compound 2; then compound 3.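

Within the data shown here, at the amide-type nitrogen, the substituent does change the read-out in this assay: 1-carboxy-2-methylpropyl in place of 2-(dimethylamino)ethyl gives a 3.5-fold higher number from compound 2 to compound 3 (0.55 log units; beyond the scatter), the only single-place change read so far. The effect is weakened but not lost with the carboxylic acid on this chain. No measured property is available to account for this step.

Still open, from the compounds shown here alone, is whether the step follows from losing the dimethylamino group, gaining the carboxylic acid, or the branching and defined stereocentre. A methyl ester or a 2-hydroxyethyl chain at this nitrogen would help separate these.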